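Chloro for ethyl in the sulfonamide series

The source may hold more compounds than are shown below. What is called first, only, known or untested is meant among the compounds shown, and "the series" means these compounds.

Values in a functional assay on MDA-MB-231 cells (Homo sapiens) for antiproliferative activity, read by sulforhodamine B assay, with a stated time of 48 h; a higher number here means a weaker inhibitor, a lower number a stronger inhibitor:
- Compound 1 `CCc1cccc(NS(=O)(=O)c2ccc(N3CCNC3=O)cc2)c1`: 1410 nM
- Compound 2 `COc1cc(NS(=O)(=O)c2ccc(N3CCNC3=O)cc2)cc(OC)c1OC`: 45 nM
- Compound 3 `O=C1NCCN1c1ccc(S(=O)(=O)Nc2cccc(Br)c2)cc1`: 290 nM

Compound 1 has the highest number of the three, with compound 3 nearest and compound 2 furthest. Compound 4 `O=C1NCCN1c1ccc(S(=O)(=O)Nc2cccc(Cl)c2)cc1` is not yet measured. Its difference from compound 1 is chloro in place of ethyl on an aromatic carbon, with chloro in place of ethyl on an aromatic carbon, meta to a large group. Within the data shown here, the one measured step that bears on this is a 4.9-fold lower number from compound 1 to compound 3 (0.69 log units; beyond the scatter), bromo in place of ethyl on an aromatic carbon. Among the measured compounds shown here, no chloro compound has been measured, so the expectation rests on that step alone: a similar move toward a lower number in this assay. The expected step is a 4.0-fold lower number from compound 1 to compound 4 (0.61 log units; beyond the scatter). For compound 4 the estimate is 350 nM, with an expected range of 140 nM to 900 nM.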

Compound 4, half-maximal inhibitory concentration: 200 nM
Beside the measured number, compound 4's estimate is 1.8-fold (0.24 log units) above it, within the range that was stated.
By their numbers in this assay, from the lowest: compound 2; then compounds 4 and 3 (each within the scatter of the next); then compound 1.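

In this assay, the move away from ethyl at this position now holds for a second halogen, chloro, and the step is again beyond the scatter (a 7.1-fold lower number from compound 1 to compound 4 (0.85 log units; beyond the scatter)). Chloro and bromo cannot be told apart here (a 1.5-fold lower number from compound 3 to compound 4 (0.16 log units; within the scatter)), so the two halogens read as equivalent at this position within the compounds shown. No measured property is available to explain why either halogen gives a lower number than ethyl.

Going by these compounds, whether an amine, a carboxylic acid or a longer chain at this position would match the halogens remains open. On these data alone, whether fluoro would follow chloro and bromo is equally open.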